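Changing the Ring on the Carbonyl Carbon of Compound 3

The source may report more compounds than this note shows. Statements on the series, on what has been measured and on what is new or still open speak of the compounds shown alone.

Of the compounds shown here, three built on one shared core have been measured in a functional assay on H184B5F5/M10 cells (Homo sapiens) for antiproliferative activity, read by XTT assay, with a stated time of 72 h; on this read-out higher numbers stand for weaker inhibition and lower numbers for stronger inhibition. Compound 1 `COc1ccc(-c2cc3ccccc3nc2/C=C/C(=O)c2ccc(O)cc2)cc1` gives 5690 nM. Compound 2 `COc1ccc(-c2cc3ccccc3nc2/C=C/C(=O)c2ccc(OC)c(OC)c2)cc1` gives 7240 nM. Compound 3 `COc1ccc(-c2cc3ccccc3nc2/C=C/C(=O)c2ccccn2)cc1` gives 4140 nM. Compound 3 holds the lowest of the three numbers, but its gaps to the other two both lie within the scatter, so on these data the three compounds cannot be told apart.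

Compound 4 `COc1ccc(-c2cc3ccccc3nc2/C=C/C(=O)c2sccc2N)cc1` has not been measured. It differs from compound 3 in a single place: 3-aminothiophen-2-yl in place of pyridin-2-yl on a carbonyl carbon.

All three measured steps exchange the ring on that same carbonyl carbon, and each stayed within the scatter: a 1.3-fold higher number from compound 1 to compound 2 (0.10 log units; within the scatter), a 1.4-fold lower number from compound 1 to compound 3 (0.14 log units; within the scatter) and a 1.7-fold lower number from compound 2 to compound 3 (0.24 log units; within the scatter). Going by the values given here, the ring on the carbonyl carbon has therefore made no clear difference in this assay so far. The new ring of compound 4 is of a kind not present among the measured compounds, which adds some uncertainty, but nothing measured points to a shift in either direction. The expected step is a 1.0-fold lower number from compound 3 to compound 4 (0.01 log units; within the scatter), that is, none beyond the scatter. For compound 4 the estimate in this assay is 4000 nM, with a range from 1500 nM to 11000 nM.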

Compound 4, half-maximal inhibitory concentration: > 10000 nM
Compound 4 ended at the assay's limit; the forecaster's own chance of this, stated with the estimate: 5%; at least 2.5-fold (0.39 log units) between middle value and limit.
By their numbers in this assay, from the lowest: compounds 3, 1 and 2 (each within the scatter of the next). At a limit, above all of these: compound 4.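

In this assay, going by these compounds alone, the ring on the carbonyl carbon makes a readable difference for the first time: 3-aminothiophen-2-yl in place of pyridin-2-yl gives an at least 2.4-fold higher number from compound 3 to compound 4 (0.38 log units; beyond the scatter), so this position does not accept every ring equally. Going by these compounds, compound 4 sits at a limit of the assay rather than at a number, so only the floor of this step is known and its true size stays open: the limit of > 10000 nM in this assay, at which 1 of the 4 values shown sits. The other two steps, an at least 1.7-fold higher number from compound 1 to compound 4 (0.24 log units; that floor lies within the scatter) and an at least 1.3-fold higher number from compound 2 to compound 4 (0.14 log units; that floor lies within the scatter), cannot be read, since neither floor clears the scatter and compound 4 cannot be placed against compound 1 or compound 2.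

The change from compound 3 to compound 4 swaps the six-membered ring for a five-membered ring containing sulfur and also brings in an amine, and the compounds shown do not separate the two, since neither a plain thiophen-2-yl ring nor a pyridin-2-yl ring carrying an amine is among them. Also open, on these data alone, is whether a furan-2-yl ring, with oxygen in place of sulfur, would behave like pyridin-2-yl or like 3-aminothiophen-2-yl.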